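Adding a Second Bromo Group to Compound 2

A few compounds are considered here, and "the series" means these few. Any claim that something is new, unique, unknown or untested is made for them only; others in the source may bear on it.

Of the compounds shown here, three built on a shared core have been tested in a functional assay on the whole organism for inhibition, with Rattus norvegicus as the target, read by paw edema, in the formalin test, with a stated time of 2 h, at a dose of 100 mg/kg by the intraperitoneal route; a lower number here means less inhibition, a higher number more inhibition at the dose given (going by the name of the read-out). Compound 1, `O=c1cc(CNc2nc(-c3cc4cc(Br)cc(Br)c4oc3=O)cs2)c2cc(Cl)ccc2[nH]1`, gives 17.8%. Compound 2, `Cc1cccc2c(CNc3nc(-c4cc5cc(Br)ccc5oc4=O)cs3)cc(=O)[nH]c12`, gives 9.19%. Compound 3, `O=c1cc(CNc2nc(-c3cc4cc(Br)ccc4oc3=O)cs2)c2ccc(Cl)cc2[nH]1`, gives 9.09%. Among these three numbers compound 2 stands second highest, but its nearest neighbour, compound 3, lies only marginally lower, within the usual scatter, and even the highest number, that of compound 1, sits within the usual scatter of compound 2, so no order can be read among the three.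

The next compound in the series, compound 4, `Cc1cccc2c(CNc3nc(-c4cc5cc(Br)cc(Br)c5oc4=O)cs3)cc(=O)[nH]c12`, has not yet been measured in this assay. It is derived from compound 2 by a single change: bromo in place of hydrogen on an aromatic carbon. For the measured compounds named here, no pair of the measured compounds differs in exactly this way, so the size of the step cannot be read from a measured example.

Given that all three measured numbers fall within the scatter of one another, the expected step of a number 2.8 percentage points higher from compound 2 to compound 4 (within the scatter) is small, with a slight upward lean drawn from the number of compound 1, 17.8%, which also carries two bromo groups. Compound 4 is therefore estimated at 12%, within a range of 3% to 24%.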

Compound 4, a percentage reported as inhibition, in the whole organism at one dose (the size of the read-out at that dose, not a potency): 16.3%
Estimate against measurement, compound 4: 4.3 percentage points below, and the stated range covers the measured number.
By their numbers in this assay, from the lowest: compounds 3, 2, 4 and 1 (each within the scatter of the next).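

The change of bromo in place of hydrogen on an aromatic carbon now has a measured example of its own: in this assay the step is a number 7.1 percentage points higher from compound 2 to compound 4 (within the scatter). The pair shows that a bromo group can stand at this place, ortho to a fused ring and meta to the other bromo group, with the number staying within the scatter of compound 2, so it supports neither a real gain nor a real loss from this change. No measurement bears on what lies behind the size of this step.

On these data alone, it remains open whether another group at this same place, such as a methoxy group, an amine or a carboxylic acid, would give a step that stands clear of the scatter. As far as these compounds go, it is also open whether bromo in place of hydrogen at this position would give a similar step on the other compounds, and whether a reading at a single dose and time would hold at other doses, since this one pair is all that speaks to the change.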